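The source may hold more compounds than are shown below. What is called first, only, known or untested is meant among the compounds shown, and "the series" means these compounds.

Measured compounds and their growth inhibition:

- compound 1 `COc1cc(C2CC(c3ccc(Br)cc3)=NN2C(C)=O)ccc1OCc1cn(Cc2ccc([N+](=O)[O-])cc2)nn1`: 0%
- compound 2 `COc1cc(C2CC(c3cc(OC)c(OC)c(OC)c3)=NN2C(C)=O)ccc1OCc1cn(Cc2ccc([N+](=O)[O-])cc2)nn1`: 68%
- compound 3 `COc1ccc(C2CC(c3ccc(OCc4cn(Cc5ccc([N+](=O)[O-])cc5)nn4)cc3)=NN2C(C)=O)cc1OC`: 11%

In a functional assay on A549 cells (Homo sapiens) for inhibition, read by sulforhodamine B assay, tested at 10 uM (on this read-out higher numbers stand for more inhibition of growth at the one concentration tested and lower numbers for less inhibition of growth), compound 1 gives the lowest of the three numbers. Compound 3 lies nearest to it, and compound 2 lies furthest, with both gaps beyond the scatter. For the measured compounds named here, the one step that changes a single place is a number 68 percentage points higher from compound 1 to compound 2 (beyond the scatter), which swaps the whole aryl group on the carbon with a double bond to nitrogen.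

Compound 4 `COc1cc(C2CC(c3ccc(Cl)cc3)=NN2C(C)=O)ccc1OCc1cn(Cc2ccc([N+](=O)[O-])cc2)nn1` differs from compound 1 by chloro in place of bromo on an aromatic carbon. Going by the values given here, no measured step touches this halogen swap; the only recorded step replaces the whole 4-bromophenyl group rather than a single substituent, so it bears on the present change only loosely, and nothing in the three numbers allows a direction to be read off. The expected change in this assay is therefore none beyond the scatter, a number 5 percentage points higher from compound 1 to compound 4 (within the scatter). Compound 4 is estimated at 5%, within a range from 0% to 20%.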

Compound 4, percent growth inhibition at one concentration: 0%
Compound 4: the middle estimate sits 5 percentage points above what was measured; the measured number falls inside the stated range.
By their numbers in this assay, from the lowest: compounds 1 and 4 (each within the scatter of the next); then compound 3; then compound 2.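

In this assay, chloro in place of bromo on an aromatic carbon para to a large group gives no change at the digits printed from compound 1 to compound 4 (within the scatter), so the two halogens cannot be told apart at this position on this read-out. Replacing 3,4,5-trimethoxyphenyl with 4-chlorophenyl gives a number 68 percentage points lower from compound 2 to compound 4 (beyond the scatter), so the large gap to compound 2 is not confined to the 4-bromophenyl group. No evidence on the cause of either step is available.

Going by these compounds, whether an amino group or a carboxylic acid on the same aromatic carbon would lift growth inhibition remains open. Also open, on these data alone, is which of the methoxy groups of compound 2 accounts for its gap to compound 1 and compound 4, and whether a single methoxy group would be enough.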